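Cytotoxicity notes: hexyl to pentyl chain step

The source may hold more compounds than are shown below. What is called first, only, known or untested is meant among the compounds shown, and "the series" means these compounds.

Measured so far:
compound 1 `CCCCCCc1cc2cn(COCCO)c(=O)nc2o1` — > 200000 nM
compound 2 `OCCOCn1cc2ccnc-2nc1O` — > 200000 nM

In a functional assay on HEL cells (Homo sapiens) (on this read-out lower numbers stand for higher toxicity in this test and higher numbers for lower toxicity in this test), compound 1 gives > 200000 nM, which is a limit of the assay and not a number. In this assay compound 2 gives > 200000 nM, again a limit rather than a number. Among the measured compounds shown here, both results sit at the same point, as the limit of > 200000 nM in this assay, at which 2 of the 2 values shown sit, records, so no measured step between two compounds exists and nothing orders compound 1 against compound 2 on this read-out.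

Compound 3 `CCCCCc1cc2cn(COCCO)c(=O)nc2o1` has not been measured. It differs from compound 1 by hydrogen in place of methyl on a saturated chain carbon, five bonds along the chain from an aromatic carbon. For the measured compounds named here, there is no measured step to build on, and the only known values are limits. The expected step is a number no higher from compound 1 to compound 3 (the limit leaves the size open), none beyond the scatter. Compound 3 is therefore estimated at 200000 nM, with a range from 100000 nM to 400000 nM, and is most likely to be reported again only as a limit.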

Compound 3, half-maximal cytotoxic concentration: > 200000 nM
Compound 3 was reported as a limit; the forecaster's own chance of this, stated with the estimate: 90%; the middle value sits exactly at the limit.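

In this assay compound 3 gives > 200000 nM, a limit of the assay and not a number. No step can be read between compound 1 and compound 3. The compounds shown leave open whether hydrogen in place of methyl at this chain carbon changes the read-out at all: the limit of > 200000 nM in this assay, at which 3 of the 3 values shown sit.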